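The source may report more compounds than this note shows. Statements on the series, on what has been measured and on what is new or still open speak of the compounds shown alone.

- Compound 1 `COc1ccc(NC(=O)CN2CCN(c3nnc(Cc4ccncc4)c4ccccc34)CC2)cc1OC` gives 40100 nM
- Compound 2 `O=C(CN1CCN(c2nnc(Cc3ccncc3)c3ccccc23)CC1)Nc1ccc(Br)cc1` gives 1990 nM

In a functional assay on HT-29 cells (Homo sapiens) for cytotoxicity, read by MTT assay, with a stated time of 72 h (on this read-out higher numbers stand for weaker inhibition and lower numbers for stronger inhibition), compound 2 at 1990 nM holds the lower of the two numbers. Compound 3 `Cc1ccc(F)cc1NC(=O)CN1CCN(c2nnc(Cc3ccncc3)c3ccccc23)CC1` changes one group of compound 2: 5-fluoro-2-methylphenyl in place of 4-bromophenyl on an amide-type nitrogen leaves the rest untouched. Within the data shown here, the only measured step at this place, a 20-fold lower number from compound 1 to compound 2 (1.30 log units; beyond the scatter), is large, so a swap here can move the number strongly. Among the measured compounds shown here, no measured compound carries the 5-fluoro-2-methylphenyl group, so the direction is uncertain, though a moderate rise seems likeliest. The expected change is a 2.5-fold higher number from compound 2 to compound 3 (0.40 log units; beyond the scatter) as estimated. For compound 3 the estimated value is 5000 nM, with an expected range from 1000 nM to 25000 nM.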

Compound 3, half-maximal inhibitory concentration: 470 nM
Compound 3: middle estimate off by 11-fold (1.03 log units), on the high side, outside the stated range (below it).
By their numbers in this assay, from the lowest: compound 3; then compound 2; then compound 1.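

In this assay the gain at this amide-type nitrogen does not stop at 4-bromophenyl: 5-fluoro-2-methylphenyl gives a 4.2-fold lower number from compound 2 to compound 3 (0.63 log units; beyond the scatter) and so extends the range among the three groups to an 85-fold lower number from compound 1 to compound 3 (1.93 log units; beyond the scatter). These steps show that this position tolerates a substituted phenyl ring carrying two small groups, but nothing measured here explains why this swap lowers the number. On these data alone, whether the fluorine or the methyl matters more remains open. So does the effect of a plain phenyl ring, or of a phenyl ring carrying an amine or a carboxylic acid.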